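The source may hold more compounds than are shown below. What is called first, only, known or untested is meant among the compounds shown, and "the series" means these compounds.

Series notes, step from compound 3 to compound 4.

Three compounds of the shared core carry numbers in an ADME assay on GES1 cells (Homo sapiens) for inhibition, read by MTT assay, with a stated time of 72 h; a lower number here means a stronger inhibitor, a higher number a weaker inhibitor. Compound 1 `Cc1cc(Nc2cc(-c3cccs3)[nH]n2)n2nc(SCc3ccc(Br)cc3)nc2n1` gives 38700 nM in this assay. Compound 2 `Cc1cc(Nc2cc(-c3ccccc3)[nH]n2)n2nc(SCc3ccccc3Br)nc2n1` gives 41100 nM in this assay. Compound 3 `Cc1cc(Nc2cc(-c3ccc(F)cc3)[nH]n2)n2nc(SCc3ccc(Br)cc3)nc2n1` gives 34200 nM in this assay, the lowest of the three numbers, but its gap to compound 1 and to compound 2 each lies within the scatter, so no order among the three is established.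

Compound 4 `Cc1cc(Nc2cc(-c3ccccc3)[nH]n2)n2nc(SCc3ccc(Br)cc3)nc2n1` is not yet measured in this assay. Against compound 3 the difference is hydrogen in place of fluoro on an aromatic carbon; cut one bond further out it reads 4-fluorophenyl to phenyl.

Among the compounds with values here, no measured step removes a fluoro on this ring. Within the data shown here, the one measured step on the same aromatic carbon position is a 1.1-fold lower number from compound 1 to compound 3 (0.05 log units; within the scatter), a change of the whole aryl group that moved nothing beyond the scatter. Among the measured compounds shown here, compound 2 also carries phenyl at this position, but its bromine sits elsewhere, so it yields no single-change step; its value and that of compound 3 merely lie within the scatter of each other.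

The expectation is therefore a step of a 1.1-fold higher number from compound 3 to compound 4 (0.02 log units; within the scatter), nothing beyond the scatter in either direction. Compound 4 is estimated at 36000 nM in this assay, with a range from 18000 nM to 72000 nM.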

Compound 4, half-maximal inhibitory concentration: 39300 nM
For compound 4 the middle estimate is 1.1-fold (0.04 log units) below the measured one; the measured number falls inside the stated range.
By their numbers in this assay, from the lowest: compounds 3, 1, 4 and 2 (each within the scatter of the next).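

In this assay, within the data shown here, hydrogen in place of fluoro gives a 1.1-fold higher number from compound 3 to compound 4 (0.06 log units; within the scatter), the first single-change reading of this substituent on the six-membered aromatic ring of carbon only, para to a large group, and it does not separate the two. With the 4-bromophenyl kept, phenyl in place of thiophen-2-yl gives a 1.0-fold higher number from compound 1 to compound 4 (0.01 log units; within the scatter), so among the three aryl groups shown, phenyl, 4-fluorophenyl and thiophen-2-yl, no step leaves the scatter. Among these compounds, compound 4 also makes compound 2 readable for the first time in a single change: 4-bromophenyl in place of 2-bromophenyl gives a 1.0-fold lower number from compound 2 to compound 4 (0.02 log units; within the scatter), so the place of the bromine on this benzyl ring is not resolved either in these compounds.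

The data shown offer no explanation for why these steps remain within the scatter. Still open, going by these compounds, is whether any change at these two places can move the number beyond the scatter, for instance an amine or a carboxylic acid on the phenyl ring, or a longer chain between the sulfur and the bromophenyl.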